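The source may report more compounds than this note shows. Statements on the series, on what has been measured and on what is new or still open speak of the compounds shown alone.

Measured compounds and their values in a functional assay on RKO cells (Homo sapiens) for inhibition, read by MTT assay, with a stated time of 48 h; on this read-out higher numbers stand for weaker inhibition and lower numbers for stronger inhibition:
Compound 1 `Cc1nc(N(C)c2ccc([Se]C#N)c(Cl)c2)c2ccccc2n1` gives 11 nM.
Compound 2 `COc1ccc(N(C)c2nc(C)nc3ccccc23)cc1C(=O)OCCC[Se]C#N` gives 1140 nM.
Compound 3 `C[Se]c1ccc(N(C)c2nc(C3CC3)nc3ccccc23)cc1` gives 21 nM.

Compound 2 stands with the highest of the three numbers. Its nearest neighbour, compound 3, lies lower by a margin beyond the scatter, and compound 1 lies lower still. Compound 4 `COc1ccc(N(C)c2nc(C)nc3ccccc23)cc1[Se]C` keeps the core of compound 2 and its methoxy group and changes one substituent: a group of 2 heavy atoms (1 carbon, 1 selenium; no ring) in place of a group of 9 heavy atoms (5 carbon, 1 nitrogen, 2 oxygen, 1 selenium; no ring), on an aromatic carbon. Going by the values given here, no measured pair in this set shows the same exchange, so the size of the step cannot be read from a measured step. Among the compounds with values here, what can be said is that the group entering compound 4 is of the same kind as the one carried by compound 3, and compound 3 gives 21 nM, whereas compound 2 gives 1140 nM. On that basis a large step toward stronger inhibition, beyond the scatter, is expected in this assay . Compound 4 is estimated at 40 nM, within a range from 8 nM to 200 nM. This estimate means an expected step of a 29-fold lower number from compound 2 to compound 4 (1.45 log units; beyond the scatter).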

Compound 4, half-maximal inhibitory concentration: 11 nM
Beside the measured number, compound 4's estimate is 3.6-fold (0.56 log units) above it; the measured number falls inside the stated range.
By their numbers in this assay, from the lowest: compounds 1, 4 and 3 (each within the scatter of the next); then compound 2.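

In this assay, going by these compounds alone, the exchange on this aromatic carbon, ortho to a methoxy group, gives a 100-fold lower number from compound 2 to compound 4 (2.02 log units; beyond the scatter) and is the first step in the set that can be read between two measured compounds. With the core and the methoxy group unchanged, it shows that the substituent at this place alone can move the number by a large margin, well beyond the scatter. Nothing shown explains the size of this step. The compounds shown leave open which part of the departing group of 9 heavy atoms accounts for the step, as a shorter chain ending in the same nitrile would begin to tell. They also leave open whether the selenium of the entering group matters, and how a methylthio group or a carboxylic acid would read at this place.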